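A few compounds are considered here, and "the series" means these few. Any claim that something is new, unique, unknown or untested is made for them only; others in the source may bear on it.

Measured so far:
- compound 1, `Cn1c(-c2ccc(NC(=O)CSc3nc4cc(Cl)ccc4o3)cc2)nc(-c2ccccc2)c1-c1ccccc1`: 2.5%
- compound 2, `Cn1nnnc1SCC(=O)Nc1ccc(-c2nc(-c3ccccc3)c(-c3ccccc3)n2C)cc1`: 34.3%
- compound 3, `CN(C)/C=C/N1CCN(CC(=O)Nc2ccc(-c3nc(-c4ccccc4)c(-c4ccccc4)n3C)cc2)CC1`: 1.9%

In a functional assay on MCF7 cells (Homo sapiens) for cytotoxicity, read by MTT assay, with a stated time of 24 h, tested at 1.6 ug/mL (on this read-out higher numbers stand for a stronger effect at the one concentration tested and lower numbers for a weaker effect), compound 3 gives the lowest of the three numbers, but its gap to compound 1 lies within the scatter, so the two cannot be ordered; only compound 2 stands apart, see a number 32.4 percentage points lower from compound 2 to compound 3 (beyond the scatter) and a number 0.6 percentage points lower from compound 1 to compound 3 (within the scatter).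

Compound 4, `COc1ccc(CN2CCN(CC(=O)Nc3ccc(-c4nc(-c5ccccc5)c(-c5ccccc5)n4C)cc3)CC2)cc1`, differs from compound 3 as follows: 4-methoxybenzyl in place of 2-(dimethylamino)ethenyl on an amine nitrogen in a ring

Going by the values given here, no measured step touches the amine nitrogen in the ring; the steps of a number 31.8 percentage points higher from compound 1 to compound 2 (beyond the scatter) and a number 32.4 percentage points lower from compound 2 to compound 3 (beyond the scatter) concern the group on the chain carbon bound to the carbonyl carbon and do not bear on this change. The only reference is that the shared core with a piperazine on that carbon sits at the low end in compound 3. Compound 4 is therefore expected to stay close to compound 3, with a step of a number 4.1 percentage points higher from compound 3 to compound 4 (within the scatter) and a wide range. The estimate for compound 4 is 6%, between 0% and 28%.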

Compound 4, a percentage reported as activity, at one concentration (the size of the read-out at that concentration, not a potency): 27.3%
Compound 4: the middle estimate sits 21.3 percentage points below what was measured; measured number inside the range.
By their numbers in this assay, from the lowest: compounds 3 and 1 (each within the scatter of the next); then compounds 4 and 2 (each within the scatter of the next).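

In this assay the amine nitrogen in the ring proves a position that responds, with a number 25.4 percentage points higher from compound 3 to compound 4 (beyond the scatter) on 4-methoxybenzyl replacing 2-(dimethylamino)ethenyl. A piperazine on the chain carbon therefore does not by itself hold the shared core at the low end, as compound 3 alone suggested. No measurement at hand accounts for this step.

Open, from the compounds shown here alone, is whether a plain benzyl or a simple methyl on that nitrogen would give a similar number. That would show whether the step goes with the aromatic ring or with its methoxy group.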